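The source may report more compounds than this note shows. Statements on the series, on what has been measured and on what is new or still open speak of the compounds shown alone.

Among the measured compounds shown here, in a functional assay on HepG2 cells (Homo sapiens) for cytotoxicity, read by MTT assay, with a stated time of 48 h (on this read-out higher numbers stand for weaker inhibition and lower numbers for stronger inhibition), compound 1 `COc1ccccc1-c1nnc(SCCn2c([N+](=O)[O-])cnc2C)o1` gives 10000 nM, the highest of the two numbers known here; the other compound, compound 2 `Cc1ncc([N+](=O)[O-])n1CCSc1nnc(-c2ccc([N+](=O)[O-])cc2)o1`, gives 4100 nM, a lower figure whose gap from compound 1 lies beyond the scatter. Compound 3 `Cc1ncc([N+](=O)[O-])n1CCSc1nnc(-c2cnccc2N)o1` differs from compound 1 in one place: 4-aminopyridin-3-yl in place of 2-methoxyphenyl on an aromatic carbon. For the measured compounds named here, no measured pair shows a change of this kind, so the data give no step size for it. Compound 3 is therefore expected to give about 10000 nM, with a range from 4000 nM to 30000 nM. That estimate means a step of no change at the digits printed from compound 1 to compound 3 (within the scatter), no larger than the scatter and in no settled direction.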

Compound 3, half-maximal inhibitory concentration: 8400 nM
Beside the measured number, compound 3's estimate is 1.2-fold (0.08 log units) above it; the measured number falls inside the stated range.
By their numbers in this assay, from the lowest: compound 2; then compounds 3 and 1 (each within the scatter of the next).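

Putting 4-aminopyridin-3-yl in place of 2-methoxyphenyl gives a 1.2-fold lower number from compound 1 to compound 3 (0.08 log units; within the scatter) in this assay, so on this aromatic carbon a ring with a hetero atom and an amine, carrying a hydrogen-bond donor, can replace the carbon-only ring without a change that stands clear of the scatter. Nothing available here gives a reason for this result. On these data alone, what stays open is how a plain pyridin-3-yl or a 2-aminophenyl would behave at this position, which would separate the ring nitrogen from the amine, and what a carboxylic acid on the ring would do.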